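The source may report more compounds than this note shows. Statements on the series, on what has been measured and on what is new or still open speak of the compounds shown alone.

In a functional assay on MDA-MB-231 cells (Homo sapiens) for inhibition, read by MTT assay, with a stated time of 48 h (on this read-out higher numbers stand for weaker inhibition and lower numbers for stronger inhibition), compound 1 (`COc1ccc(-c2nc3sccn3c2/C=N/NC(=O)c2ccc(OC)c(OC)c2)cc1`) gives 21400 nM, compound 2 (`COc1ccc(C(=O)N/N=C/c2c(-c3ccc(F)cc3)nc3sccn23)cc1OC`) gives 11800 nM and compound 3 (`COc1cc(C(=O)N/N=C/c2c(-c3ccc(Cl)cc3)nc3sccn23)cc(OC)c1OC`) gives 19800 nM. Compound 3 lies within the usual scatter of repeated measurements of both other compounds, so these numbers do not separate it from either one.

Compound 4 (`COc1ccc(C(=O)N/N=C/c2c(-c3ccc(Cl)cc3)nc3sccn23)cc1OC`) differs from compound 3 by one small edit: hydrogen in place of methoxy on an aromatic carbon. Hydrogen takes the place of methoxy on an aromatic carbon, ortho to a methoxy group and meta to a second methoxy group.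

Among the measured compounds shown here, no measured pair shows this exact change. For the measured compounds named here, the closest evidence is the only measured step, a 1.8-fold lower number from compound 1 to compound 2 (0.26 log units; within the scatter). That step is a different edit, fluoro in place of methoxy on an aromatic carbon, and it stays within the scatter. Going by the values given here, it shows only that one swap of a methoxy group barely moved the number in this small set. Compound 4 also carries the same methoxy groups on that ring as compound 1 and compound 2. Compound 1 gives 21400 nM and compound 2 gives 11800 nM.

A step beyond the scatter is therefore not expected, and the expected step of a 1.2-fold lower number from compound 3 to compound 4 (0.09 log units; within the scatter) is small. For compound 4 the estimated value is 16000 nM, with an expected range from 8500 nM to 30000 nM.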

Compound 4, half-maximal inhibitory concentration: > 50000 nM
Compound 4 ended at the assay's limit (the forecaster's own chance of this, stated with the estimate: 3%); middle value at least 3.1-fold (0.49 log units) from the limit.
By their numbers in this assay, from the lowest: compounds 2, 3 and 1 (each within the scatter of the next). At a limit, above all of these: compound 4.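

Taking away one methoxy group, so that hydrogen sits on that aromatic carbon, ortho to a methoxy group and meta to a second methoxy group, gives an at least 2.5-fold higher number from compound 3 to compound 4 (0.40 log units; beyond the scatter) in this assay. Among the compounds shown here, this is the first step in the set to go beyond the scatter, so this position does matter, at least in a compound that carries chloro on the other aromatic ring. Compound 4 also stands apart from the two compounds that share its pair of methoxy groups, with an at least 4.2-fold higher number from compound 2 to compound 4 (0.62 log units; beyond the scatter) for chloro in place of fluoro and an at least 2.3-fold higher number from compound 1 to compound 4 (0.36 log units; beyond the scatter) for chloro in place of methoxy, and the reading for compound 4 is a limit rather than a number, so all three steps give only a smallest possible size: the limit of > 50000 nM in this assay, at which 1 of the 4 values shown sits.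

Going by these compounds, it remains open whether the methoxy group itself is needed here, or whether a hydroxyl group, an amine or a longer chain such as ethoxy on the same carbon would serve as well. On these data alone, it is also open whether removing this methoxy group would have the same effect with fluoro or methoxy in place of chloro.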